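Removing the hydroxy from the ring nitrogen of compound 2

The compounds below may be only part of what the source reports. "The series", "measured", "known", "first", "only" and "open" are said of these compounds alone.

Compound 1 `C/C=C\C[C@@H](C)C[C@@H](C)/C(O)=C1/C(=O)N/C(=C\c2ccc(O)cc2)C1=O`: > 40000 nM
Compound 2 `C=C[C@@H]1C[C@H](C)C[C@H](C)C1c1c(O)ccn(O)c1=O`: 1830 nM

In a functional assay on K562 cells (Homo sapiens) for inhibition, read by MTT assay, with a stated time of 48 h (on this read-out higher numbers stand for weaker inhibition and lower numbers for stronger inhibition), compound 1 gives only > 40000 nM, which is a limit of the assay and not a number (the limit of > 40000 nM in this assay, at which 1 of the 2 values shown sits). In this assay compound 2 gives 1830 nM, the only true number among the two shown. Compound 3 `C=C[C@@H]1C[C@H](C)C[C@H](C)C1c1c(O)cc[nH]c1=O` is not yet measured and differs from compound 2 in one place (hydrogen in place of hydroxy on an aromatic nitrogen). Going by the values given here, no measured step is available to size this change, so the expectation rests on compound 2 alone and carries a wide range. Compound 3 is expected to show weaker inhibition, with an estimated step of a 3.3-fold higher number from compound 2 to compound 3 (0.52 log units; beyond the scatter), giving an estimate of 6000 nM between 1500 nM and 25000 nM.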

Compound 3, half-maximal inhibitory concentration: > 40000 nM
Compound 3: a limit, no number; the forecaster's own chance of this, stated with the estimate: 15%; middle value at least 6.6-fold (0.82 log units) away from the limit.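

Replacing the hydroxy on the aromatic nitrogen with hydrogen gives, in this assay, an at least 21-fold higher number from compound 2 to compound 3 (1.33 log units; beyond the scatter), so among the compounds shown this single oxygen atom carries a large share of the inhibition. The value of compound 3 is a limit and not a number, so this step marks only the smallest size the change can have: the limit of > 40000 nM in this assay, at which 2 of the 3 values shown sit.

Still open, on these data alone, is whether the hydroxy itself is required, or whether another group on that nitrogen, such as methoxy or an amine, would keep the inhibition. The compounds shown also do not tell how this change produces its effect.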